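From 3,4,5-trihydroxyphenyl to 4-nitrophenyl on a shared core

The compounds below may be only part of what the source reports. "The series", "measured", "known", "first", "only" and "open" are said of these compounds alone.

Compound 1 `O=C(CCc1nc2ccccc2c(=O)[nH]1)N/N=C/c1ccc(O)cc1` gives 238000000 nM
Compound 2 `O=C(CCCc1nc2ccccc2c(=O)[nH]1)N/N=C/c1cc(O)c(O)c(O)c1` gives 78000000 nM
Compound 3 `COc1cc(/C=N/NC(=O)CCCc2nc3ccccc3c(=O)[nH]2)cc(O)c1O` gives 88000000 nM

In a physicochemical assay, read by spectrophotometry, with a stated time of 30 min (a lower number here means a stronger inhibitor, a higher number a weaker inhibitor), compound 2 gives 78000000 nM and stands at the low end of the three numbers, level within the scatter with compound 3 at 88000000 nM on that scale. Compound 1 has a clearly higher number (238000000 nM) than the other two. Going by the values given here, the only measured step (a 1.1-fold higher number from compound 2 to compound 3 (0.05 log units; within the scatter)) puts a methyl in place of hydrogen on an oxygen on an aromatic ring.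

The change in question leads to compound 4 `O=C(CCCc1nc2ccccc2c(=O)[nH]1)N/N=C/c1ccc([N+](=O)[O-])cc1` and places 4-nitrophenyl in place of 3,4,5-trihydroxyphenyl on a carbon with a double bond to nitrogen on the otherwise unchanged structure. The measured step touches a single oxygen while this change replaces the whole group, so it sets no size for what follows. Compound 2 differs from compound 1 in more than one place, so compound 1 offers only a weak guide with its higher number (238000000 nM) on the same scale. A higher number is therefore expected in this assay, with an estimated 3.2-fold higher number from compound 2 to compound 4 (0.51 log units; beyond the scatter) and wide uncertainty. The expected value for compound 4 is 250000000 nM within a range of 90000000 nM to 800000000 nM as an estimate.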

Compound 4, half-maximal inhibitory concentration: 316000000 nM
Estimate against measurement, compound 4: 1.3-fold (0.10 log units) below; the measured number falls inside the stated range.
By their numbers in this assay, from the lowest: compounds 2 and 3 (each within the scatter of the next); then compounds 1 and 4 (each within the scatter of the next).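

In this assay, the exchange of the whole 3,4,5-trihydroxyphenyl group for 4-nitrophenyl on a carbon with a double bond to nitrogen gives a 4.1-fold higher number from compound 2 to compound 4 (0.61 log units; beyond the scatter). Going by these compounds alone, the earlier step at this group, a 1.1-fold higher number from compound 2 to compound 3 (0.05 log units; within the scatter), touched a single oxygen and stayed within the scatter, so this is the first sign, among compounds differing in one place, that the number moves beyond the scatter when the group at this position is changed. Nothing available explains this difference between the two groups.

The single step changes the ring's substituents all at once: the entering group has 0 hydrogen-bond donors where the leaving group has 3, and it brings a nitro group, so the compounds shown cannot separate the loss of the hydroxyl groups from the arrival of the nitro group. Also open, as far as these compounds go, is where an unsubstituted phenyl group or a 4-aminophenyl group on the same carbon, with the rest of the structure unchanged, would stand on this scale relative to compound 2 and compound 4.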